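The source may hold more compounds than are shown below. What is called first, only, known or untested is meant among the compounds shown, and "the series" means these compounds.

In an ADME assay on HEK293 cells (Homo sapiens) for cytotoxicity, read by MTT assay, with a stated time of 72 h (a lower number here means a stronger inhibitor, a higher number a weaker inhibitor), compound 1 `O=C(CN1CCN(C(=O)c2ccc(Br)cc2)CC1)N1CCN(CCCc2c[nH]c3ccc(F)cc23)CC1` gives 60500 nM and compound 2 `COc1ccc(C(=O)N2CCN(CC(=O)N3CCN(CCCc4c[nH]c5ccc(OC)cc45)CC3)CC2)cc1` gives 190000 nM. Compound 2 therefore stands highest of the two numbers, and its gap to compound 1 lies beyond the scatter. Compound 3 `COc1ccc2[nH]cc(CCCN3CCN(C(=O)CN4CCN(C(=O)c5ccc(Br)cc5)CC4)CC3)c2c1`, not yet measured in this assay, departs from compound 2 at one place: bromo in place of methoxy on an aromatic carbon. This is bromo in place of methoxy on an aromatic carbon, with 4-methoxyphenyl becoming 4-bromophenyl. Among the compounds with values here, no step between measured compounds differing in one place is available, so this change has no direct precedent. Within the data shown here, the only indirect guide is compound 1 at 60500 nM, which also carries the 4-bromophenyl group but differs from compound 2 elsewhere as well. A modest move toward a lower number in this assay is expected, of a size near the scatter rather than clearly beyond it. The expected change is a 1.8-fold lower number from compound 2 to compound 3 (0.26 log units; within the scatter). For compound 3 the estimated value is 105000 nM, with an expected range from 50000 nM to 210000 nM.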

Compound 3, half-maximal inhibitory concentration: 80500 nM
The estimate for compound 3 lay 1.3-fold (0.12 log units) above the measured number; the range from low to high includes it.
By their numbers in this assay, from the lowest: compounds 1 and 3 (each within the scatter of the next); then compound 2.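

In this assay, within the data shown here, the step of a 2.4-fold lower number from compound 2 to compound 3 (0.37 log units; beyond the scatter) gives the first direct reading for the aromatic carbon para to a large group: the change from 4-methoxyphenyl to 4-bromophenyl, with nothing else altered, is modest but beyond the scatter. The second single-place comparison concerns an aromatic carbon of the core, where a 1.3-fold higher number from compound 1 to compound 3 (0.12 log units; within the scatter) stays within the scatter, so with 4-bromophenyl held fixed, fluoro and methoxy at that carbon are not separated in this cytotoxicity read-out. Of the two places, only the aromatic ring bearing the bromo or methoxy group therefore shows a step beyond the scatter, and no measurement at hand accounts for either step.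

The compounds shown leave open whether the bromo-for-methoxy step keeps its size when fluoro rather than methoxy sits on the core, since that single-place pair is absent from this set. They also leave open how other groups at the same aromatic carbon, such as chloro, nitrile or an amine, would compare with bromo and methoxy.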